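A 4-(pyridin-4-yl)piperazin-1-yl Group Replaces the Chain of Compound 1

The compounds below may be only part of what the source reports. "The series", "measured", "known", "first", "only" and "open" are said of these compounds alone.

In a functional assay on PC-3 cells (Homo sapiens) for inhibition, read by CellTiter-Glo, with a stated time of 72 h (on this read-out higher numbers stand for lower toxicity in this test and lower numbers for higher toxicity in this test), compound 1 `CC1=C(CC(=O)NCCN(C)C)c2cc(F)ccc2/C1=C\c1nc2ccccc2s1` gives 4880 nM. For the measured compounds named here, its only measured neighbour, compound 2 `CC1=C(CC(=O)N(C)CCN(C)C)c2cc(F)ccc2/C1=C\c1nc2ccccc2s1`, gives 5880 nM, so the two stand within the scatter of each other. The next structure, compound 3 `CC1=C(CC(=O)N2CCN(c3ccncc3)CC2)c2cc(F)ccc2/C1=C\c1nc2ccccc2s1`, keeps the shared core but changes the group on the carbonyl carbon: 4-(pyridin-4-yl)piperazin-1-yl in place of (2-(dimethylamino)ethyl)amino on a carbonyl carbon. Going by the values given here, only one measured step touches this part of the molecule. Methyl in place of hydrogen on an amide-type nitrogen gives a 1.2-fold higher number from compound 1 to compound 2 (0.08 log units; within the scatter). Among the compounds with values here, that step is small, but it covers a far smaller change than the exchange of the whole group, and no measured compound carries a ring at this place. The data therefore give no direction for the new group in this assay, and the expectation is for little net change, held with wide uncertainty. The expected step is a 1.1-fold lower number from compound 1 to compound 3 (0.04 log units; within the scatter). For compound 3 the estimated value is 4500 nM, with an expected range from 1500 nM to 15000 nM.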

Compound 3, half-maximal cytotoxic concentration: 12300 nM
The estimate for compound 3 lay 2.7-fold (0.44 log units) below the measured number, and the stated range covers the measured number.
By their numbers in this assay, from the lowest: compounds 1 and 2 (each within the scatter of the next); then compound 3.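

In this assay, the exchange of the open chain for 4-(pyridin-4-yl)piperazin-1-yl on a carbonyl carbon gives a 2.5-fold higher number from compound 1 to compound 3 (0.40 log units; beyond the scatter) and a 2.1-fold higher number from compound 2 to compound 3 (0.32 log units; beyond the scatter). This shows that the number at this place can move beyond the scatter, which the methyl on the amide-type nitrogen did not do, with a 1.2-fold higher number from compound 1 to compound 2 (0.08 log units; within the scatter); among these three compounds, the group carrying the rings stands on the side of lower toxicity in this test than either chain, though both steps are modest. Nothing available here bears on what lies behind this rise.

The compounds shown leave open whether the higher number goes with the six-membered non-aromatic ring alone or also needs the pyridine ring, a question that a piperazine bearing a methyl group, or a morpholine, on the same carbonyl carbon would address. Also open, on these data alone, is whether a phenyl ring in place of the pyridine ring, or a longer chain ending in a dimethylamino group, would shift the number further.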